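An ether in place of the propyl ester

A few compounds are considered here, and "the series" means these few. Any claim that something is new, unique, unknown or untested is made for them only; others in the source may bear on it.

Compound 1 `CCc1cccc2c(O)c(-c3occ(C)c3C(=O)O)ccc12` gives 7 ug/mL in a functional assay on KBVIN cells (Homo sapiens) for cytotoxicity, read by MTT assay, with a stated time of 72 h; on this read-out lower numbers stand for an effect already at smaller amounts and higher numbers for an effect only at larger amounts of compound. Compound 2 `CCCOC(=O)c1c(C)coc1-c1ccc2c(CC)cccc2c1OC`, in which the acid is esterified and the hydroxyl methylated, is reported in this assay only as the limit > 10 ug/mL. Compound 3 `CCc1cccc2c(OC)c(-c3occ(C)c3C(=O)On3nnc4ccccc43)ccc12` is likewise reported only as the limit > 10 ug/mL. Among the measured compounds shown here, the one measured step, a step that the two limits leave unreadable from compound 2 to compound 3, therefore shows no readable size, as the limit of > 10 ug/mL in this assay, at which 2 of the 3 values shown sit, leaves both ends open. Compound 4 `CCOCc1c(C)coc1-c1ccc2c(CC)cccc2c1OC` differs from compound 2 by ethoxymethyl in place of propoxycarbonyl on an aromatic carbon. For the measured compounds named here, no measured step bears on this change, and compound 2 itself stands at a limit, so the expected step that the limit leaves unreadable from compound 2 to compound 4 is essentially unconstrained. Compound 4 is therefore estimated to fall near the same limit, at 12 ug/mL, within 4 ug/mL to 35 ug/mL.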

Compound 4, concentration for half-maximal effect: > 10 ug/mL
Compound 4 was reported as a limit; the forecaster's own chance of this, stated with the estimate: 65%; the middle value is on the limit's open side.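

Compound 2 and compound 4 are both reported only as limits in this assay, so no step can be read between them: the limit of > 10 ug/mL in this assay, at which 3 of the 4 values shown sit. The compounds shown leave open whether ethoxymethyl in place of propoxycarbonyl changes the read-out at all.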